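The compounds below may be only part of what the source reports. "The series", "measured", "known", "first", "only" and "open" are said of these compounds alone.

Of the compounds shown here, three built on one shared core have been measured in an assay for inhibition of Fatty-acid amide hydrolase 1 (Rattus norvegicus), using a Dixon plot, with a stated time of 6 h; a lower number here means a stronger inhibitor, a higher number a weaker inhibitor. Compound 1 `CCOS(=O)(=O)/C=C/c1ccc(-c2cnc(C(=O)CCCCCCc3ccccc3)o2)nc1` gives 0.2 nM in this assay, compound 2 `C[S+]([O-])/C=C/c1ccc(-c2cnc(C(=O)CCCCCCc3ccccc3)o2)nc1` gives 0.9 nM, and compound 3 `N#CCCCCCc1cnc(C(=O)CCCCCCc2ccccc2)o1` gives 4 nM. Compound 3 therefore stands highest of the three numbers; the value of compound 2 lies nearest to it and the value of compound 1 furthest from it. Within the data shown here, the only step between two measured compounds that differ in a single place is the one a 4.5-fold higher number from compound 1 to compound 2 (0.65 log units; beyond the scatter), in which a smaller sulfur-bearing group replaces a larger one on the unsaturated chain that carries the aromatic system.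

Compound 4 `CSCCCCCc1cnc(C(=O)CCCCCCc2ccccc2)o1` differs from compound 3 in one place as well: methylsulfanyl in place of cyano on a saturated chain carbon, five bonds along the chain from an aromatic carbon. The step between compound 1 and compound 2 is the closest guide, since it too exchanges one terminal group on a chain for another, yet it concerns a different chain and a different pair of groups, so its size is only a rough pointer. A modest change in this assay, in either direction, is the most that can be read from it. Compound 4 is expected to give about 5 nM in this assay, with a likely range from 1.5 nM to 15 nM. Such a result would correspond to an expected step of a 1.3-fold higher number from compound 3 to compound 4 (0.10 log units; within the scatter).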

Compound 4, inhibition constant: 6.1 nM
Estimate against measurement, compound 4: 1.2-fold (0.09 log units) below; the range from low to high includes it.
By their numbers in this assay, from the lowest: compound 1; then compound 2; then compounds 3 and 4 (each within the scatter of the next).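

In this assay, replacing cyano with methylsulfanyl on a saturated chain carbon, five bonds along the chain from an aromatic carbon, gives a 1.5-fold higher number from compound 3 to compound 4 (0.18 log units; within the scatter), so the two compounds cannot be told apart in this measure. Among these compounds, this is the first reading of a change on this saturated chain, and it shows that these two terminal groups, which have the same heavy-atom count and differ in their atoms and in the triple bond of the cyano group, are not separated here, unlike the groups on the unsaturated chain in a 4.5-fold higher number from compound 1 to compound 2 (0.65 log units; beyond the scatter). The compounds shown offer no evidence on why the exchange leaves the number within the scatter.

As far as these compounds go, what remains open is whether this tolerance holds only for this pair or extends to other end groups on the same chain, such as an amine, a carboxylic acid, methylsulfinyl or methylsulfonyl, or to a longer chain. How compound 3 and compound 4 relate to compound 1 and compound 2 cannot be read as single changes, since they differ from those two in more than one place.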